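This account rests on a few compounds, and the source may have more. Where it says the series, first, only, none or still open, it means among the compounds named here.

Compound 1, `CN(CCNCc1cn(CCCO)nn1)CCNc1ccnc2cc(Cl)ccc12`, gives > 200000 nM in a functional assay on NCI-H460 cells (Homo sapiens) for antiproliferative activity, read by sulforhodamine B assay, with a stated time of 72 h; a higher number here means a weaker inhibitor, a lower number a stronger inhibitor; that is a limit of the assay, not a number.
Compound 2, `CN(CCNCc1cn(-c2nc3ccccc3[nH]2)nn1)CCNc1ccnc2cc(Cl)ccc12`, gives 33000 nM in this assay.

Compound 2 thus holds the only real number shown, the other value being (the limit of > 200000 nM in this assay, at which 1 of the 2 values shown sits). Within the data shown here, the single measured step, an at least 6.0-fold lower number from compound 1 to compound 2 (0.78 log units; beyond the scatter), came from putting an aromatic bicycle in place of a short chain. Compound 3, `CN(CCNCc1cn(-c2ccnc3cc(Cl)ccc23)nn1)CCNc1ccnc2cc(Cl)ccc12`, changes that same spot: 7-chloroquinolin-4-yl in place of 1H-benzimidazol-2-yl on an aromatic nitrogen. Since one aromatic bicycle replaces another, a far smaller shift than the measured step is expected, likely within scatter, so compound 3 is estimated at 20000 nM, between 5000 nM and 70000 nM, a step of a 1.7-fold lower number from compound 2 to compound 3 (0.22 log units; within the scatter).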

Compound 3, half-maximal inhibitory concentration: 16000 nM
Estimate against measurement, compound 3: 1.3-fold (0.10 log units) above; measured number inside the range.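

Swapping one aromatic bicycle for another still moves the number at this position: 7-chloroquinolin-4-yl in place of 1H-benzimidazol-2-yl gives a 2.1-fold lower number from compound 2 to compound 3 (0.31 log units; beyond the scatter), so which bicycle sits there matters, if only modestly. Against the 3-hydroxypropyl chain, the same group gives an at least 12-fold lower number from compound 1 to compound 3 (1.09 log units; beyond the scatter), a large step. The value of compound 1 is a limit of the assay, not a number: the limit of > 200000 nM in this assay, at which 1 of the 3 values shown sits.

Still open, on these data alone, is whether a single phenyl ring at this position would match either bicycle. Also open, as far as these compounds go, is whether quinolin-4-yl without its chlorine would keep the number of compound 3.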